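A few compounds are considered here, and "the series" means these few. Any claim that something is new, unique, unknown or untested is made for them only; others in the source may bear on it.

Measured compounds:
compound 1 `CCN1CCc2c(c(C)nn2C(=O)Nc2ccc(Br)cc2)C1` — 1.7%
compound 2 `CCN1CCc2c(c(C(C)(C)C)nn2C(=O)Nc2ccc(Br)cc2)C1` — 0%

In a functional assay on the whole organism (strain Swiss albino) for inhibition, with Mus musculus as the target, in the formalin test, with stated times of 30 min and 5 min, at a dose of 100 mg/kg (on this read-out lower numbers stand for less inhibition and higher numbers for more inhibition at the one dose given (going by the name of the read-out)), compound 1 gives 1.7%, and compound 2 gives 0%; these two numbers lie within the usual scatter of each other, so on the data shown compound 2 cannot be told apart from compound 1, and both show close to no inhibition. For the measured compounds named here, the only measured step, a number 1.7 percentage points lower from compound 1 to compound 2 (within the scatter), concerns a change on an aromatic carbon of the shared core rather than the group on the amide-type nitrogen, so it gives no direct guide to the change at hand. Compound 3 `CCN1CCc2c(c(C(C)(C)C)nn2C(=O)Nc2ccc(C)cc2C)C1` differs from compound 2 in one place: 2,4-dimethylphenyl in place of 4-bromophenyl on an amide-type nitrogen. Going by the values given here, with no measured step bearing on this kind of change and both measured compounds near zero, the expected step is a number 3 percentage points higher from compound 2 to compound 3 (within the scatter), nothing beyond the scatter. Compound 3 is therefore estimated to give 3% in this assay, with a range from 0% to 15%.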

Compound 3, a percentage reported as inhibition, in the whole organism at one dose (the size of the read-out at that dose, not a potency): 15.7%
Compound 3: middle estimate off by 12.7 percentage points, on the low side; the whole stated range lies below it.
By their numbers in this assay, from the lowest: compounds 2 and 1 (each within the scatter of the next); then compound 3.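

In this assay, the group on the amide-type nitrogen proves able to shift the result (a number 15.7 percentage points higher from compound 2 to compound 3 (beyond the scatter)), a modest step but one beyond the scatter, whereas the earlier change on an aromatic carbon of the shared core stayed within it. Among the compounds shown, 2,4-dimethylphenyl in place of 4-bromophenyl is thus the first single change that clearly moves this read-out, though only at the one dose given. No measurement is available that explains this rise.

The step swaps the bromine for two methyl groups at once, so it cannot show whether losing the bromine, gaining either methyl, or the combination accounts for the rise. Also open, from the compounds shown here alone, is how a plain phenyl, a 4-methylphenyl or a phenyl carrying an amine or a carboxylic acid would behave on this nitrogen.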